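The compounds below may be only part of what the source reports. "The series", "measured", "known", "first", "only" and "open" are said of these compounds alone.

Compound 1 `COc1ccc(OC)c(S(=O)(=O)NC(=O)c2ccc(Cn3ccc4ccc(NC(=O)CC5CCCC5)cc43)c(OC)c2)c1`: 9.1
Compound 2 `CCCCC(CC)C(=O)Nc1ccc2ccn(Cc3ccc(C(=O)NS(=O)(=O)c4ccc(OC)cc4)cc3OC)c2c1`: 7.4
Compound 3 `COc1cc(C(=O)NS(=O)(=O)c2cc(C)ccc2C)ccc1Cn1ccc2ccc(NC(=O)CC3CCCC3)cc21`: 8.4

In a functional assay (trachea) for antagonist activity, with Cavia porcellus as the target (a lower number here means a less potent compound, a higher number a more potent compound, by a factor of ten per unit of this negative logarithm), compound 2 gives 7.4 and is the least potent of the three, since compound 3 gives 8.4 and compound 1 gives 9.1. Compound 4 `CCCCC(CC)C(=O)Nc1ccc2ccn(Cc3ccc(C(=O)NS(=O)(=O)c4ccc([N+](=O)[O-])cc4)cc3OC)c2c1` has not yet been measured in this assay. It differs from compound 2 by nitro in place of methoxy on an aromatic carbon. Going by the values given here, the only measured step that touches the ring attached to the sulfonyl sulfur is a number 0.70 log units lower from compound 1 to compound 3 (beyond the scatter); it exchanges two groups at once and involves no nitro, so it shows only that altering the substitution of this ring can move the number modestly. Among the compounds with values here, no step here exchanges a methoxy for a nitro, and no measured compound carries a nitro at all. Within the data shown here, the bearing of the one relevant step is thus indirect, and little movement beyond the scatter is expected in either direction. The expected step is a number 0.10 log units higher from compound 2 to compound 4 (within the scatter). Compound 4 is therefore estimated to give 7.5, with a range from 6.8 to 8.3.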

Compound 4, negative logarithm of the antagonist equilibrium constant: 7.7
The estimate for compound 4 lay 0.20 log units below the measured number; the range from low to high includes it.
By their numbers in this assay, from the lowest: compounds 2 and 4 (each within the scatter of the next); then compound 3; then compound 1.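

In this assay, replacing 4-methoxyphenyl with 4-nitrophenyl on the sulfonyl sulfur gives a number 0.30 log units higher from compound 2 to compound 4 (within the scatter) and so does not separate the two groups at this place, para to a large group. The earlier step on this ring, a number 0.70 log units lower from compound 1 to compound 3 (beyond the scatter), exchanged two groups at once, whereas here a single group is exchanged and the number stays within the scatter, so this position accepts both methoxy and nitro on the background of compound 2. Nothing given here speaks to why the two groups read alike.

The compounds shown leave open whether an amine or a carboxylic acid at this place would also stay within the scatter of compound 2. They also leave open whether nitro in place of methoxy would read the same alongside the amide chain of compound 3.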